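Moving chlorines on the benzyl ring of compound 1

The source may report more compounds than this note shows. Statements on the series, on what has been measured and on what is new or still open speak of the compounds shown alone.

Compound 1 `C[C@H](NC(=O)C(=O)NCc1ccc(Cl)cc1)C(=O)N[C@@H](CC(=O)O)C(=O)COc1c(F)c(F)cc(F)c1F` has the lowest number of the three measured compounds in a functional assay on Jurkat cells (Homo sapiens) (on this read-out lower numbers stand for stronger inhibition and higher numbers for weaker inhibition), giving 8.4 nM. Compound 2 `C[C@H](NC(=O)C(=O)NCc1ccc(F)cc1)C(=O)N[C@@H](CC(=O)O)C(=O)COc1c(F)c(F)cc(F)c1F` gives 197 nM, and compound 3 `C[C@H](NC(=O)C(=O)NCc1cccc(Cl)c1Cl)C(=O)N[C@@H](CC(=O)O)C(=O)COc1c(F)c(F)cc(F)c1F` gives 76 nM. The change to compound 4 `C[C@H](NC(=O)C(=O)NCc1cc(Cl)ccc1Cl)C(=O)N[C@@H](CC(=O)O)C(=O)COc1c(F)c(F)cc(F)c1F` is 2,5-dichlorophenyl in place of 4-chlorophenyl on a saturated chain carbon bound to an amide-type nitrogen. The closest measured step is a 9.0-fold higher number from compound 1 to compound 3 (0.96 log units; beyond the scatter), where 4-chlorophenyl likewise became a dichlorophenyl; the step of a 23-fold higher number from compound 1 to compound 2 (1.37 log units; beyond the scatter) shows that even a small change on this ring costs a great deal. Because a 9.0-fold higher number from compound 1 to compound 3 (0.96 log units; beyond the scatter) was clearly beyond the scatter, a weaker compound 4 is expected, with a step of a 7.1-fold higher number from compound 1 to compound 4 (0.85 log units; beyond the scatter). Compound 4 is therefore estimated at 60 nM, expected to fall between 15 nM and 250 nM.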

Compound 4, half-maximal inhibitory concentration: 4.3 nM
For compound 4 the middle estimate is 14-fold (1.14 log units) above the measured one, and the stated range ends above it.
By their numbers in this assay, from the lowest: compounds 4 and 1 (each within the scatter of the next); then compound 3; then compound 2.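

Adding a second chlorine need not cost anything at this position: in this assay, a 2.0-fold lower number from compound 1 to compound 4 (0.29 log units; within the scatter) separates 4-chlorophenyl from 2,5-dichlorophenyl, so the two compounds cannot be told apart. Where the chlorines sit counts for more than how many there are, as the two dichlorophenyl groups give an 18-fold lower number from compound 3 to compound 4 (1.25 log units; beyond the scatter), while replacing 4-fluorophenyl gives a 46-fold lower number from compound 2 to compound 4 (1.66 log units; beyond the scatter) in the same direction. Nothing measured here explains these differences. Still open, going by these compounds, is how this ring would behave carrying a methoxy group or a nitrile in place of chlorine.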